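Working notes: from compound 2 to compound 3

The source may hold more compounds than are shown below. What is called first, only, known or untested is meant among the compounds shown, and "the series" means these compounds.

Compound 1 `CC(C)=CCOc1ccc2c(c1)OC(c1cccc(F)c1)CC2=O`: 4280 nM
Compound 2 `CC(C)=CCOc1ccc2c(c1)OC(c1ccccc1Br)CC2=O`: 3180 nM
Compound 3 `COc1ccc(C2CC(=O)c3ccc(OCC=C(C)C)cc3O2)cc1`: not yet measured

Going by the values given here, in a functional assay (on this read-out higher numbers stand for weaker inhibition and lower numbers for stronger inhibition), only compound 1 and compound 2 have numbers so far, and the two lie within the scatter of each other, so no order can be read between them. Compound 1 and compound 2 therefore stand level, with compound 2 at 3180 nM in this assay.

The next change is 4-methoxyphenyl in place of 2-bromophenyl on a saturated ring carbon, next to the ring oxygen.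

Among the compounds with values here, one measured step bears on it, since it also exchanges the group at a saturated ring carbon: a 1.3-fold lower number from compound 1 to compound 2 (0.13 log units; within the scatter). That step stays within the scatter. Within the data shown here, no measured compound carries 4-methoxyphenyl, so this single step is thin support and the range is kept wide. No step beyond the scatter is expected in this assay, and no direction is favoured. The expected step is a 1.1-fold higher number from compound 2 to compound 3 (0.04 log units; within the scatter). The estimated value for compound 3 is 3500 nM, with an expected range from 1500 nM to 8000 nM.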

Compound 3, half-maximal inhibitory concentration: 10200 nM
Beside the measured number, compound 3's estimate is 2.9-fold (0.46 log units) below it; the measured number lies above the stated range.
By their numbers in this assay, from the lowest: compounds 2 and 1 (each within the scatter of the next); then compound 3.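

In this assay, the group on this saturated ring carbon, next to the ring oxygen, now makes a readable difference: 4-methoxyphenyl in place of 2-bromophenyl gives a 3.2-fold higher number from compound 2 to compound 3 (0.51 log units; beyond the scatter), and 4-methoxyphenyl in place of 3-fluorophenyl gives a 2.4-fold higher number from compound 1 to compound 3 (0.38 log units; beyond the scatter). The earlier exchange of one halogen-bearing phenyl group for the other gave only a 1.3-fold lower number from compound 1 to compound 2 (0.13 log units; within the scatter), so the position looked flat until 4-methoxyphenyl entered, and both new steps point to weaker inhibition, though each is modest in size. Nothing at hand accounts for the shift.

The compounds shown leave open whether the step belongs to the methoxy group itself or to its place on the phenyl ring, as 4-methoxyphenyl differs from 2-bromophenyl and 3-fluorophenyl in both substituent and substitution pattern, and 2-methoxyphenyl or 4-bromophenyl would separate the two. They also leave open how this position responds to an amine or a carboxylic acid on the phenyl ring, as all three groups here are neutral phenyl rings.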